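Hydroxy in place of methyl on the aniline ring

The compounds below may be only part of what the source reports. "The series", "measured", "known", "first", "only" and "open" are said of these compounds alone.

Compound 1, `CC(C)(C)c1cc(NC(=O)Nc2ccc(Nc3ncnc4c3OCCN4)cc2)no1`, in an assay on isolated protein for inhibition of proto-oncogene tyrosine-protein kinase receptor Ret variant V804L (Homo sapiens), read by 33P incorporation, with stated times of 15 min and 40 min; on this read-out lower numbers stand for stronger inhibition and higher numbers for weaker inhibition: 58 nM
Compound 2, `Cc1cc(NC(=O)Nc2cc(C(C)(C)C)on2)ccc1Nc1ncnc2c1OCCN2`, in this assay: 85 nM
Compound 3, `CC(C)(C)c1cc(NC(=O)Nc2cccc(Nc3ncnc4c3OCCN4)c2)no1`, in this assay: 6550 nM

Among these three numbers compound 2 has the second highest. Its nearest neighbour is compound 1, and the step of a 1.5-fold higher number from compound 1 to compound 2 (0.17 log units; within the scatter) lies within the scatter, so the two cannot be ordered. Compound 3, with a different point of attachment of the shared core to the urea-bearing ring, gives 6550 nM, far from compound 2 and beyond the scatter.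

The unmeasured compound 4, `CC(C)(C)c1cc(NC(=O)Nc2ccc(Nc3ncnc4c3OCCN4)c(O)c2)no1`, differs from compound 2 by hydroxy in place of methyl on an aromatic carbon. Among the compounds with values here, the only measured step that touches this position is a 1.5-fold higher number from compound 1 to compound 2 (0.17 log units; within the scatter), which shows that putting a methyl there changes little. Nothing measured here speaks to a hydroxy at the same place, so the expectation rests on that single step alone.

For compound 4 in this assay the account therefore expects a step of about a 1.1-fold higher number from compound 2 to compound 4 (0.02 log units; within the scatter), that is, no change beyond the scatter. The estimated value for compound 4 is 90 nM, with a range from 35 nM to 300 nM.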

Compound 4, half-maximal inhibitory concentration: 163 nM
Beside the measured number, compound 4's estimate is 1.8-fold (0.26 log units) below it; the range from low to high includes it.
By their numbers in this assay, from the lowest: compounds 1, 2 and 4 (each within the scatter of the next, the first and the last beyond it); then compound 3.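

In this assay the exchange itself gives a 1.9-fold higher number from compound 2 to compound 4 (0.28 log units; within the scatter) and so does not separate hydroxy from methyl on this aromatic carbon, ortho to a large group and meta to a large group. Within the data shown here, measured against hydrogen on that carbon, the picture is sharper: hydroxy gives a 2.8-fold higher number from compound 1 to compound 4 (0.45 log units; beyond the scatter) and is the first change here at this position to go beyond the scatter, although the step is modest, while methyl gave only a 1.5-fold higher number from compound 1 to compound 2 (0.17 log units; within the scatter) and stayed within it. The position is therefore not indifferent to every group placed on it, but no measurement available here accounts for the difference between hydrogen and hydroxy.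

Going by these compounds, it remains open whether a methoxy, a fluorine or an amine on this carbon would stay close to compound 2 or move further from compound 1. On these data alone, it is also open whether hydroxy would give a step of similar size on compound 3, where the shared core is attached to the urea-bearing ring at a different point.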